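The compounds below may be only part of what the source reports. "The series", "measured", "known", "first", "only" and "open" are said of these compounds alone.

Measured so far:
compound 1 `Nc1scc(CN2CCN(c3cccnc3)CC2)c1C(=O)c1ccc(Cl)cc1` – 3.2%
compound 2 `Nc1scc(CN2CCN(c3ccc(C(F)(F)F)cc3)CC2)c1C(=O)c1cccc(C(F)(F)F)c1` – -12%

In a functional assay on CHO cells with adenosine receptor A1 (Homo sapiens) as the target, read by cAMP accumulation and immunoassay, with a stated time of 6 min, tested at 0.01 uM (a lower number here means a stronger effect, a higher number a weaker effect of the compound at the concentration tested), compound 1 gives 3.2%, the higher of the two numbers; compound 2 gives -12%, which lies beyond the scatter from compound 1. Going by the values given here, no single-change step links these two compounds, so their values are stated without further comparison. Compound 3 `Nc1scc(CN2CCN(c3cccc(Cl)c3)CC2)c1C(=O)c1ccc(Cl)cc1` has not been measured. It differs from compound 1 as follows: 3-chlorophenyl in place of pyridin-3-yl on an amine nitrogen in a ring. With both known values near zero, the step of a number 3.2 percentage points lower from compound 1 to compound 3 (within the scatter) is expected to be small, within the scatter. For compound 3 the estimated value is 0%, with a range from -15% to 15%.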

Compound 3, a percentage reported as activity, at one concentration (the size of the read-out at that concentration, not a potency): -3.1%
The estimate for compound 3 lay 3.1 percentage points above the measured number; low and high end bracket the measured number.
By their numbers in this assay, from the lowest: compounds 2, 3 and 1 (each within the scatter of the next, the first and the last beyond it).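

In this assay the first single-change pair gives a number 6.3 percentage points lower from compound 1 to compound 3 (within the scatter) and so shows that, on the amine nitrogen of this ring, 3-chlorophenyl can take the place of pyridin-3-yl without a difference beyond the scatter. At this concentration, the read-out does not separate the two aromatic groups. Nothing available explains this result. On these data alone, what a benzyl group or a carboxylic acid would give at this position stays open. The single concentration also leaves open whether the two compounds would separate at other concentrations.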